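The compounds below may be only part of what the source reports. "The series", "measured", "known", "first", "only" and "open" are said of these compounds alone.

Working notes on the series. Compound 1 `FC(F)(F)c1ccccc1-c1ccc2[nH]ncc2c1` carries a trifluoromethyl on the aryl substituent of the shared core. Within the data shown here, in an assay on CHO-TREX cells for antagonist activity at transient receptor potential cation channel subfamily A member 1 (Homo sapiens), read by FLIPR and calcium flux, with a stated time of 10 min (a lower number here means a stronger inhibitor, a higher number a weaker inhibitor), compound 1 gives 164 nM, the lowest of the two numbers measured so far. Among the measured compounds shown here, compound 2 `Fc1cccc(C(F)(F)F)c1-c1ccc2[nH]ncc2c1` is the nearest neighbour: in this assay compound 2 gives 1230 nM, and the single recorded step, a 7.5-fold higher number from compound 1 to compound 2 (0.88 log units; beyond the scatter), lies beyond the scatter.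

Compound 3 `Cn1ncc2cc(-c3ccccc3C(F)(F)F)ccc21` has not yet been measured. It differs from compound 1 by methyl in place of hydrogen on an aromatic nitrogen, with the hydrogen on the aromatic nitrogen replaced and nothing else altered. For the measured compounds named here, no measured step touches this part of the molecule; the only step available, a 7.5-fold higher number from compound 1 to compound 2 (0.88 log units; beyond the scatter), concerns a fluoro on an aromatic carbon and gives no direct guide for a change on the ring nitrogen. The size and direction of the step in this assay are therefore open. As a working expectation a modest rise in the number is assumed, with wide uncertainty, so that compound 3 is expected at 600 nM, with a range of 150 nM to 3000 nM. The step this implies, a 3.7-fold higher number from compound 1 to compound 3 (0.56 log units; beyond the scatter), is an estimate only.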

Compound 3, half-maximal inhibitory concentration: 7410 nM
Compound 3: middle estimate off by 12-fold (1.09 log units), on the low side; the whole stated range lies below it.
By their numbers in this assay, from the lowest: compound 1; then compound 2; then compound 3.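

In this assay, among these compounds, the ring nitrogen of the shared core now has a measured step of its own: methyl in place of hydrogen on an aromatic nitrogen gives a 45-fold higher number from compound 1 to compound 3 (1.65 log units; beyond the scatter), whereas the earlier compounds offered only a change on an aromatic carbon, a 7.5-fold higher number from compound 1 to compound 2 (0.88 log units; beyond the scatter). Among the compounds shown here, this position is therefore sensitive to substitution, at least in the setting of compound 1, and the form with hydrogen on the nitrogen keeps the lowest number of the series so far. Nothing among the available data explains why this methyl produces so large a step.

As far as these compounds go, it remains open whether the rise belongs to methyl specifically or to any replacement of this hydrogen, and an ethyl group, a longer chain or an acetyl group on the same nitrogen could separate those readings. It is equally open whether the methyl step would carry over to compound 2, where a fluoro already sits on the aryl substituent, as the compounds shown hold no pair that tests this.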